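Swapping a sulfoxide chain for an amide on a shared core

The source may report more compounds than this note shows. Statements on the series, on what has been measured and on what is new or still open speak of the compounds shown alone.

Of the compounds shown here, two of a shared core have been measured in an assay for inhibition of 15-hydroxyprostaglandin dehydrogenase [NAD(+)] (Homo sapiens), read by fluorescence, with a stated time of 15 min, in the presence of a further agent that is not named here; a higher number here means a weaker inhibitor, a lower number a stronger inhibitor. Compound 1, `Nc1c([S+]([O-])CCCCl)sc2nc(-c3cccs3)cc(-c3ccccc3)c12`, gives 4 nM in this assay. Compound 2, `CCCC[S+]([O-])c1sc2nc(-c3nccs3)cc(-c3ccc(CO)cc3)c2c1N`, gives 2.5 nM in this assay. Compound 1 thus has the higher of the two numbers, but the gap to compound 2 lies within the usual scatter, so the two values are best read as alike.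

Compound 3, `CCCNC(=O)c1sc2nc(-c3cccs3)cc(-c3ccccc3)c2c1N`, has not yet been measured. It differs from compound 1 in one place: a group of 6 heavy atoms (4 carbon, 1 nitrogen, 1 oxygen; no ring) in place of a group of 6 heavy atoms (3 carbon, 1 oxygen, 1 sulfur, 1 chlorine; no ring), on an aromatic carbon. Among the measured compounds shown here, no measured pair shows this kind of change, so its effect on this assay cannot be read from the data at hand. Both measured compounds sit at low numbers, and the shared core is kept, so the expectation is that compound 3 stays in a similar region, with a moderate rise in the number allowed for. The step from compound 1 to compound 3 is expected to be about a 3.0-fold higher number from compound 1 to compound 3 (0.48 log units; beyond the scatter). The estimate for compound 3 in this assay is 12 nM, with a range from 3 nM to 60 nM.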

Compound 3, half-maximal inhibitory concentration: > 7500 nM
Compound 3: no number, only a limit (the forecaster's own chance of this, stated with the estimate: 5%); at least 620-fold (2.79 log units) between middle value and limit.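

In this assay compound 3 gives > 7500 nM, which is a limit of the assay and not a number. Replacing the sulfoxide chain of compound 1 with propylcarbamoyl, on the aromatic carbon next to the ring sulfur, gives an at least 1800-fold higher number from compound 1 to compound 3 (3.27 log units; beyond the scatter), even though the entering and leaving groups are equal in heavy atoms and neither contains a ring, so this position clearly does not accept every group of that size. On these data alone, the two earlier compounds both carry a sulfoxide chain here and could not show how much the inhibition depends on what sits at this place, and the full size of the step remains unknown: the limit of > 7500 nM in this assay, at which 1 of the 3 values shown sits.

As far as these compounds go, it remains open whether the loss goes with the carbonyl, with the amide hydrogen or with the absence of the sulfoxide itself, and a tertiary amide, a ketone or a sulfone at this place would help to separate these. The swap is also seen only once, on the core of compound 1, so whether it has the same effect with the other ring substituents of compound 2 cannot be read from these compounds.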